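A few compounds are considered here, and "the series" means these few. Any claim that something is new, unique, unknown or untested is made for them only; others in the source may bear on it.

Measured compounds in the series:
Compound 1 `NC(=O)c1ncn2c(=O)n(Cc3ccccc3)nnc12` gives > 50000 nM, a limit of the assay.
Compound 2 `NC(=O)c1ncn2c(=O)n(Cc3cccs3)nnc12` gives > 50000 nM, a limit of the assay.
Compound 3 `CC[C@@H](c1ccccc1)n1nnc2c(C(N)=O)ncn2c1=O` gives > 50000 nM, a limit of the assay.

All three values come from a functional assay on U-373MG ATCC cells for inhibition, with U373 MG (Homo sapiens) as the target, read by MTT assay, with a stated time of 7 days; on this read-out lower numbers stand for stronger inhibition of growth and higher numbers for weaker inhibition of growth. Compound 1 stands at the limit and no number is known for it; the same holds for the other two, as the limit of > 50000 nM in this assay, at which 3 of the 3 values shown sit, shows. The step that the two limits leave unreadable from compound 1 to compound 2 is therefore not readable in size, and neither is a step that the two limits leave unreadable from compound 1 to compound 3. Nothing measured in this series shows a step whose size can be read.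

Compound 4 `NC(=O)c1ncn2c(=O)n(C(c3ccccc3)c3ccccc3)nnc12` is the next member. Its change from compound 1 is phenyl in place of hydrogen on a saturated chain carbon bound to an aromatic carbon and an aromatic nitrogen. Within the data shown here, the measured steps that bear on this place are the one to compound 3, which changes the same saturated chain carbon, and the one to compound 2, which changes the aromatic ring on it; both sit at the limit on both sides, so they give no direction and no size. No step beyond the scatter can be expected from them in this assay, and the likeliest outcome is another limit.

Compound 4 is estimated at 60000 nM, within 15000 nM to 250000 nM. The step this estimate means is a step that the limit leaves unreadable from compound 1 to compound 4, an expectation only.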

Compound 4, concentration for 50% growth inhibition: > 50000 nM
Compound 4: only a limit was reported; the forecaster's own chance of this, stated with the estimate: 80%; the middle value does not contradict the limit.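

In this assay compound 4 gives > 50000 nM, a limit of the assay. The step between compound 1 and compound 4 therefore cannot be read in size, as both stand at the limit: the limit of > 50000 nM in this assay, at which 4 of the 4 values shown sit.

The compounds shown leave open whether any change on the saturated chain carbon of the shared core gives a readable growth inhibition value.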